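Sulfur chain: 2-hydroxyethyl to 3-hydroxypropyl

The source may report more compounds than this note shows. Statements on the series, on what has been measured and on what is new or still open speak of the compounds shown alone.

Measured in a physicochemical assay for solubility; a higher number here means a more soluble compound, a lower number a less soluble compound:
- compound 1 `CC(C)(C)Sc1c(O)nc2ccc(C(F)(F)F)cc2c1-c1cc(Cl)ccc1O`: < 1 ug/mL (a limit)
- compound 2 `OCCSc1c(O)nc2ccc(C(F)(F)F)cc2c1-c1cc(Cl)ccc1O`: 4 ug/mL

For the measured compounds named here, compound 2 holds the only actual number, 4 ug/mL. The entry for compound 1 is a limit of the assay and not a number.

Compound 3 `OCCCSc1c(O)nc2ccc(C(F)(F)F)cc2c1-c1cc(Cl)ccc1O` is still to be measured. It differs by hydroxymethyl in place of hydroxy on a saturated chain carbon, two bonds along the chain from a sulfur, which reads as 2-hydroxyethyl to 3-hydroxypropyl.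

Going by the values given here, one measured step bears on this change, and it replaced a different group on the same sulfur: an at least 4.0-fold higher number from compound 1 to compound 2 (0.60 log units; beyond the scatter). The size of that step rests on (the limit of < 1 ug/mL in this assay, at which 1 of the 2 values shown sits). It offers only a loose guide to a change within the chain.

In this assay no shift beyond the scatter is expected, and the expected step is a 1.3-fold lower number from compound 2 to compound 3 (0.12 log units; within the scatter). The estimated value for compound 3 is 3 ug/mL, with an expected range of 1.5 ug/mL to 7 ug/mL.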

Compound 3, solubility: 3 ug/mL
For compound 3 middle estimate and measured number coincide at the digits printed; the measured number falls inside the stated range.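

In this assay, hydroxymethyl in place of hydroxy on a saturated chain carbon, two bonds along the chain from a sulfur, gives a 1.3-fold lower number from compound 2 to compound 3 (0.12 log units; within the scatter), so this position tolerates 2-hydroxyethyl and 3-hydroxypropyl without a difference that can be read. 3-Hydroxypropyl in place of tert-butyl on the sulfur gives an at least 3.0-fold higher number from compound 1 to compound 3 (0.47 log units; beyond the scatter), which makes two hydroxy-ended chains with a step beyond the scatter from the tert-butyl compound. The entry for compound 1 is a limit and not a number, so both steps from it have no upper bound: the limit of < 1 ug/mL in this assay, at which 1 of the 3 values shown sits.

Going by these compounds, whether a longer hydroxy-ended chain, or a chain ending in an amine or a carboxylic acid, would move the number beyond the scatter from compound 2 remains open. Also open, on these data alone, is whether an unbranched propyl chain on the sulfur would match the hydroxy-ended chains or stay nearer the tert-butyl compound.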